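Pentylselanyl to methylsulfanyl on the shared core

This account rests on a few compounds, and the source may have more. Where it says the series, first, only, none or still open, it means among the compounds named here.

Measured compounds in a functional assay on MCF7 cells (Homo sapiens) for cytotoxicity, read by MTT assay, with a stated time of 72 h; on this read-out higher numbers stand for weaker inhibition of growth and lower numbers for stronger inhibition of growth:
compound 1 `CCCCC[Se]c1nc(NCc2ccccc2)c2ccccc2n1` gives 50 nM;
compound 2 `CSc1nc(Nc2ccccc2)c2ccccc2n1` gives 78400 nM;
compound 3 `CCCCC[Se]c1nc(NCc2ccc(SC)cc2)c2ccccc2n1` gives 34700 nM.

Compound 3 stands second highest of the three numbers in this assay. Its nearest neighbour is compound 2, which gives a higher number still; its furthest is compound 1. Within the data shown here, the one step in the set, a 690-fold higher number from compound 1 to compound 3 (2.84 log units; beyond the scatter), concerns the methylsulfanyl on the phenyl ring and says nothing about the core substituent.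

Compound 4 `CSc1ccc(CNc2nc(SC)nc3ccccc23)cc1` differs from compound 3 thus: a group of 2 heavy atoms (1 carbon, 1 sulfur; no ring) in place of a group of 6 heavy atoms (5 carbon, 1 selenium; no ring), on an aromatic carbon. The change sits on the aromatic carbon between two ring nitrogen atoms of the shared core. Among the measured compounds shown here, no measured pair differs in this place alone, so no step bears on it directly. Compound 2 carries methylsulfanyl at the same carbon and gives a high number, but it also lacks the other two features of compound 3, so its value is only weak guidance.

For the measured compounds named here, with no step to lean on, a small movement is expected, most likely toward a still higher number: compound 4 is estimated at 60000 nM, within 15000 nM to 200000 nM, which means an expected step of a 1.7-fold higher number from compound 3 to compound 4 (0.24 log units; within the scatter).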

Compound 4, concentration for 50% growth inhibition: 47300 nM
Estimate against measurement, compound 4: 1.3-fold (0.10 log units) above; the range from low to high includes it.
By their numbers in this assay, from the lowest: compound 1; then compounds 3, 4 and 2 (each within the scatter of the next, the first and the last beyond it).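

In this assay, among these compounds, the first direct reading of this position is a 1.4-fold higher number from compound 3 to compound 4 (0.13 log units; within the scatter) and lies within the scatter. With methylsulfanyl on the phenyl ring in place, pentylselanyl and methylsulfanyl on the aromatic carbon between two ring nitrogen atoms therefore cannot be told apart, despite the difference between 6 and 2 heavy atoms. Of the two steps in the series, only a 690-fold higher number from compound 1 to compound 3 (2.84 log units; beyond the scatter) moves the number beyond the scatter, and no measured result explains why this exchange leaves the number within it.

Going by these compounds, whether the same exchange would also read within the scatter without the methylsulfanyl on the phenyl ring remains open, so the low number of compound 1 cannot yet be credited to pentylselanyl in particular. Also open, on these data alone, is whether the selenium or the chain counts at this carbon, a question that pentylsulfanyl and methylselanyl at the same place would separate.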